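A few compounds are considered here, and "the series" means these few. Any claim that something is new, unique, unknown or untested is made for them only; others in the source may bear on it.

Of the compounds shown here, three sharing one core have been measured in a functional assay on HCT-116 cells (Homo sapiens) for cytotoxicity, read by MTT assay; a lower number here means a stronger inhibitor, a higher number a weaker inhibitor. Compound 1 `Cc1cc(O)c(C(=O)/C=C/c2ccc(F)cc2)c(=O)o1` gives > 100000 nM, which is a limit of the assay and not a number. Compound 2 `Cc1cc(O)c(C(=O)/C=C/c2ccc(F)c(F)c2)c(=O)o1` gives a measured 74900 nM. Compound 3 `CCOc1ccc(/C=C/C(=O)c2c(O)cc(C)oc2=O)cc1` gives > 100000 nM, which is also a limit and not a number. Compound 3 therefore has no number of its own and stands at the limit of > 100000 nM in this assay, at which 2 of the 3 values shown sit.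

The next compound is compound 4 `Cc1cc(O)c(C(=O)/C=C/c2ccc(C#N)cc2)c(=O)o1`. It differs from compound 3 by one change, (cyano in place of ethoxy on an aromatic carbon), with cyano in place of ethoxy on an aromatic carbon, para to a large group.

Among the measured compounds shown here, two measured steps bear on this change. For the measured compounds named here, the first is a step that the two limits leave unreadable from compound 1 to compound 3, with ethoxy in place of fluoro on an aromatic carbon, and it offers no size to carry over. The second is an at least 1.3-fold lower number from compound 1 to compound 2 (0.12 log units; that floor lies within the scatter), with fluoro in place of hydrogen on an aromatic carbon. Neither step fixes a direction for the new change, so only a small shift is expected in this assay, with a real chance of another limit. The step expected is an at least 1.1-fold lower number from compound 3 to compound 4 (0.04 log units; that floor lies within the scatter). For compound 4 the estimate is 90000 nM, with an expected range from 40000 nM to 160000 nM.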

Compound 4, half-maximal inhibitory concentration: 66000 nM
For compound 4 the middle estimate is 1.4-fold (0.13 log units) above the measured one; the range from low to high includes it.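

Among compound 1, compound 3 and compound 4, which differ only on this aromatic carbon para to a large group, only compound 4 gives a measured number in this assay, so cyano is the one group of these three that brings this position within the readable range of the assay. Cyano in place of ethoxy gives an at least 1.5-fold lower number from compound 3 to compound 4 (0.18 log units; that floor lies within the scatter), and cyano in place of fluoro gives an at least 1.5-fold lower number from compound 1 to compound 4 (0.18 log units; that floor lies within the scatter). Both steps are floors and not sizes, and as printed neither goes beyond the scatter, so the result shows a number where there was a limit but not yet a real difference between these groups, each of the other two standing at a limit of the assay: the limit of > 100000 nM in this assay, at which 2 of the 4 values shown sit.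

As far as these compounds go, the true distance of compound 1 and compound 3 from compound 4 stays open, since neither of them has a number of its own. Also open, from the compounds shown here alone, is whether a measured number at this position belongs to cyano alone or would also appear with an amine, a carboxylic acid or a longer chain in the same place.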